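A Stereocentre Flip with Both Anchors at Assay Limits

The compounds below may be only part of what the source reports. "The series", "measured", "known", "first", "only" and "open" are said of these compounds alone.

The shared core carries a thioether chain on a bicyclic amine; compound 2 is `CCCSc1nsnc1[C@@H]1CN2CCC[C@H]1C2` and its close relative compound 1 is `CCCCSc1nsnc1[C@H]1CN2CCC[C@H]1C2`. In a functional assay on the whole organism with Mus musculus as the target (a lower number here means that less compound is needed, a higher number that more compound is needed for the effect), compound 2 gives > 3 mg/kg, which is a limit of the assay rather than a number (the limit of > 3 mg/kg in this assay, at which 1 of the 2 values shown sits). Compound 1 likewise gives only a limit in this assay, > 1 mg/kg (the limit of > 1 mg/kg in this assay, at which 1 of the 2 values shown sits). Because both known results are limits, where compound 2 truly stands cannot be placed more closely than its own limit. Compound 3 is `CCCSc1nsnc1[C@H]1CN2CCC[C@H]1C2`; compared with compound 2, (the two compounds have the same atoms and bonds; at least one stereo element is drawn with a configuration in one of them and without one in the other: 1 of 3 stereo elements differ; a stereocentre at a saturated ring carbon is drawn S in compound 2 and R in compound 3). Going by the values given here, with no measured step to lean on and both anchors at limits, the step is expected to stay within the usual scatter, in no set direction: a number no higher from compound 2 to compound 3 (the limit leaves the size open). Compound 3 is therefore expected to come out near 3 mg/kg, within 1 mg/kg to 10 mg/kg, quite possibly again only as a limit.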

Compound 3, dose for half-maximal effect: > 30 mg/kg
Compound 3: a limit, no number; the forecaster's own chance of this, stated with the estimate: 70%; at least 10-fold (1.00 log units) between middle value and limit.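

In this assay, going by these compounds alone, compound 3 gives only a limit, as do compound 1 and compound 2, so no step to compound 3 from either can be read. The compounds shown leave open what dose any of the three needs, and whether the flipped stereocentre matters.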